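This account rests on a few compounds, and the source may have more. Where it says the series, first, only, none or still open, it means among the compounds named here.

Values measured in a physicochemical assay for lipophilicity, read by mass spectrometry; a lower number here means a more polar compound, a higher number a more lipophilic compound:
- Compound 1 `COc1cc2c(cc1OC)C(=O)C(C(=O)Nc1ccccc1)C2`: 2.2
- Compound 2 `COc1cc2c(cc1OC)C(=O)C(C(=O)Nc1ccc(Cl)cc1)C2`: 2.76
- Compound 3 `COc1cc2c(cc1OC)C(=O)C(C(=O)Nc1ccc(Br)cc1)C2`: 3.03

Compound 3, at 3.03, sits at the top of this small set, although the nearest step is a number 0.27 log units higher from compound 2 to compound 3 (within the scatter). Compound 4 `CCc1cccc(NC(=O)C2Cc3cc(OC)c(OC)cc3C2=O)c1` has not yet been measured. It carries 3-ethylphenyl in place of 4-bromophenyl on an amide-type nitrogen. Among the compounds with values here, the steps that bear on this change are a number 0.56 log units higher from compound 1 to compound 2 (beyond the scatter) and a number 0.83 log units higher from compound 1 to compound 3 (beyond the scatter), both modest. Neither involves an ethyl group, so they serve only as a rough guide to what one ring substituent does. No step beyond the scatter is expected in this assay, and the expected step is a number 0.07 log units higher from compound 3 to compound 4 (within the scatter). Compound 4 is estimated at 3.1, with an expected range of 2.7 to 3.5.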

Compound 4, partition coefficient: 3.11
Beside the measured number, compound 4's estimate is 0.01 log units below it; the measured number falls inside the stated range.
By their numbers in this assay, from the lowest: compound 1; then compounds 2, 3 and 4 (each within the scatter of the next, the first and the last beyond it).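

In this assay, exchanging 4-bromophenyl for 3-ethylphenyl on the amide-type nitrogen gives a number 0.08 log units higher from compound 3 to compound 4 (within the scatter), so these two groups cannot be told apart here. The other two comparisons give a number 0.35 log units higher from compound 2 to compound 4 (beyond the scatter) and a number 0.91 log units higher from compound 1 to compound 4 (beyond the scatter), which shows that a step up from the unsubstituted phenyl of compound 1 is not confined to the halogens. Nothing available accounts for these steps. The compounds shown leave open how an amine, a carboxylic acid or a longer chain on this ring would move the number, and in which direction.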